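2,4-Dichlorophenyl in place of the ring on compound 3

This account rests on a few compounds, and the source may have more. Where it says the series, first, only, none or still open, it means among the compounds named here.

Measured in a functional assay on RT-112 cells (Homo sapiens) for antiproliferative activity, read by MTT assay, with a stated time of 72 h; a higher number here means a weaker inhibitor of growth, a lower number a stronger inhibitor of growth:
compound 1 `COc1cc(Nc2ncnc3c(NC(=O)Nc4ccccc4Cl)cccc23)cc(OC)c1` gives 356 nM
compound 2 `COc1cc(Nc2ncnc3c(NC(=O)Nc4cccc(Cl)c4Cl)cccc23)cc(OC)c1` gives 63.2 nM
compound 3 `COc1cc(Nc2ncnc3c(NC(=O)Nc4ccc5c(c4)OCCO5)cccc23)cc(OC)c1` gives 2750 nM

In this assay, compound 3 stands highest of the three at 2750 nM, and so is the weakest growth inhibitor of the set. Compound 4 `COc1cc(Nc2ncnc3c(NC(=O)Nc4ccc(Cl)cc4Cl)cccc23)cc(OC)c1` has not yet been measured. It departs from compound 3 by one change, (2,4-dichlorophenyl in place of 2,3-dihydro-1,4-benzodioxin-6-yl on an amide-type nitrogen), which in words is 2,4-dichlorophenyl in place of 2,3-dihydro-1,4-benzodioxin-6-yl on an amide-type nitrogen.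

Two measured steps run the opposite way, from a chlorinated phenyl ring to the ring of compound 3. These are a 7.7-fold higher number from compound 1 to compound 3 (0.89 log units; beyond the scatter) and a 44-fold higher number from compound 2 to compound 3 (1.64 log units; beyond the scatter). Both raise the number, so the reverse change is expected to lower it. A further chloro also counted in the one case available, a 5.6-fold lower number from compound 1 to compound 2 (0.75 log units; beyond the scatter). Going by the values given here, no measured compound carries the 2,4-dichlorophenyl itself, so the size of the gain remains uncertain. A large step downward is expected, landing near the two chlorinated compounds.

The expected step is a 23-fold lower number from compound 3 to compound 4 (1.36 log units; beyond the scatter).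

For compound 4 the estimated value is 120 nM, with an expected range from 40 nM to 400 nM.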

Compound 4, concentration for 50% growth inhibition: 3060 nM
The estimate for compound 4 lay 26-fold (1.41 log units) below the measured number; the measured number lies above the stated range.
By their numbers in this assay, from the lowest: compound 2; then compound 1; then compounds 3 and 4 (each within the scatter of the next).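

In this assay, the 2,4-dichlorophenyl on the amide-type nitrogen does no better than the 2,3-dihydro-1,4-benzodioxin-6-yl it replaces, with a 1.1-fold higher number from compound 3 to compound 4 (0.05 log units; within the scatter), so a phenyl ring bearing two chloro groups does not by itself bring a low number. The pattern of chloro groups matters in this series, as 2,4-dichlorophenyl in place of 2,3-dichlorophenyl gives a 48-fold higher number from compound 2 to compound 4 (1.69 log units; beyond the scatter). Adding one chloro to the 2-chlorophenyl of compound 1 can therefore go either way: it gives a 5.6-fold lower number from compound 1 to compound 2 (0.75 log units; beyond the scatter) in one case and an 8.6-fold higher number from compound 1 to compound 4 (0.93 log units; beyond the scatter) in the other, so the earlier gain from a further chloro does not hold for every place on the ring.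

Nothing given here accounts for this opposite outcome. The compounds shown also leave open whether a 4-chlorophenyl, a 3-chlorophenyl, or a 2,3-dichlorophenyl with a methyl or methoxy group in place of one chloro would stay near compound 2 or fall in with compound 3 and compound 4.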